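The source may report more compounds than this note shows. Statements on the series, on what has been measured and on what is new or still open speak of the compounds shown alone.

Working notes on the series, three compounds measured so far.

Compound 1 `Cc1cc2ncn(-c3ccc4c(N)nc(N)nc4c3)c2cc1C` carries only hydrogen at the position of interest; in an assay on isolated protein for inhibition of Dihydrofolate reductase (Homo sapiens), read by spectrophotometry, using NADPH, with a stated time of 10 min (on this read-out higher numbers stand for weaker inhibition and lower numbers for stronger inhibition), compound 1 gives 1610 nM. Compound 2 `Cc1cc2nc(-c3nccs3)n(-c3ccc4c(N)nc(N)nc4c3)c2cc1C` has 1,3-thiazol-2-yl there, and in this assay compound 2 gives 93 nM. Compound 3 `COc1ccc(-c2nc3cc(C)c(C)cc3n2-c2ccc3c(N)nc(N)nc3c2)cc1` has 4-methoxyphenyl at the same place, and in this assay compound 3 gives 2300 nM. Compound 3 thus stands at the highest of the three numbers, with a 1.4-fold higher number from compound 1 to compound 3 (0.15 log units; within the scatter) and a 25-fold higher number from compound 2 to compound 3 (1.39 log units; beyond the scatter).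

Compound 4 `Cc1cc2nc(C3CC3)n(-c3ccc4c(N)nc(N)nc4c3)c2cc1C` is not yet measured. The change from compound 3 is cyclopropyl in place of 4-methoxyphenyl on an aromatic carbon. The measured steps that bear on it are the two leading into compound 3: a 1.4-fold higher number from compound 1 to compound 3 (0.15 log units; within the scatter), so that the 4-methoxyphenyl group itself made no difference beyond the scatter relative to hydrogen, and a 25-fold higher number from compound 2 to compound 3 (1.39 log units; beyond the scatter), which shows that a different small aromatic ring at this position can give a large gain. Going by the values given here, no measured step introduces a non-aromatic ring such as cyclopropyl, so the direction rests on weak ground. Compound 4 is expected to sit near the numbers of compound 1 and compound 3, with a 2.6-fold lower number from compound 3 to compound 4 (0.41 log units; beyond the scatter) a modest step towards lower values. The estimate for compound 4 in this assay is 900 nM, within 250 nM to 3200 nM.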

Compound 4, inhibition constant: 1160 nM
The estimate for compound 4 lay 1.3-fold (0.11 log units) below the measured number; the range from low to high includes it.
By their numbers in this assay, from the lowest: compound 2; then compounds 4, 1 and 3 (each within the scatter of the next).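

In this assay the aromatic carbon between two ring nitrogen atoms now carries a non-aromatic ring, and cyclopropyl gives a 1.4-fold lower number from compound 1 to compound 4 (0.14 log units; within the scatter) and a 2.0-fold lower number from compound 3 to compound 4 (0.30 log units; within the scatter) as well, so this read-out does not tell apart hydrogen, a group of 3 heavy atoms and a group of 8 heavy atoms. Cyclopropyl in place of 1,3-thiazol-2-yl gives a 12-fold higher number from compound 2 to compound 4 (1.10 log units; beyond the scatter). Among the groups shown only 1,3-thiazol-2-yl brings a gain beyond the scatter at this position, and compounds 3 and 4 show that a ring there does not by itself bring one. Nothing measured here bears on what sets 1,3-thiazol-2-yl apart from the other groups.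

Open, on these data alone, is whether the gain seen with compound 2 carries over to thiophen-2-yl, imidazol-2-yl or pyridin-2-yl at this place. Also open is how an amine or a carboxylic acid on this carbon would stand in this assay against the four numbers shown.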